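The compounds below may be only part of what the source reports. "The series", "measured", "known", "first", "only" and "open" are said of these compounds alone.

Three hydrazones sharing the same core, each carrying the same ether-linked side chain, have been tested in an ADME assay on HEL cells (Homo sapiens) for cytotoxicity; on this read-out higher numbers stand for lower toxicity in this test and lower numbers for higher toxicity in this test. Compound 1 `COc1cc(/C=N/NC(=O)COc2cccc3ccccc23)cc(OC)c1OC` gives 47.9 ug/mL. Compound 3 `O=C(COc1cccc2ccccc12)N/N=C/c1ccccc1[N+](=O)[O-]` gives 100 ug/mL. Compound 2 `O=C(COc1cccc2ccccc12)N/N=C/c1c(O)ccc2ccccc12` gives 1.94 ug/mL. On these three numbers compound 1 stands second highest: compound 3 sits above it by a margin beyond the usual scatter, and compound 2 sits far below it, well beyond the scatter.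

From compound 1 the step leads to compound 4 `COc1ccc(/C=N/NC(=O)COc2cccc3ccccc23)cc1OC`. The change is small: hydrogen in place of methoxy on an aromatic carbon. The rest of the molecule is untouched.

Going by the values given here, no step between two measured compounds removes a single methoxy group, so there is no direct precedent. Given how little leaves the molecule, the step in this assay is expected to be modest, most likely within the scatter or a slight move toward lower numbers. For compound 4 the value expected in this assay is 40 ug/mL, with a range from 15 ug/mL to 100 ug/mL. The step this implies is estimated as a 1.2-fold lower number from compound 1 to compound 4 (0.08 log units; within the scatter).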

Compound 4, half-maximal cytotoxic concentration: 52.6 ug/mL
For compound 4 the middle estimate is 1.3-fold (0.12 log units) below the measured one, within the range that was stated.
By their numbers in this assay, from the lowest: compound 2; then compounds 1, 4 and 3 (each within the scatter of the next, the first and the last beyond it).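

Going by these compounds alone, the three earlier compounds offered no pair differing in one place, so this is the first direct look at a single change on this ring. In this assay, replacing the methoxy group with hydrogen, on a carbon ortho to a methoxy group and meta to a large group, gives a 1.1-fold higher number from compound 1 to compound 4 (0.04 log units; within the scatter). At this position, then, the loss of this one methoxy group leaves no readable mark on the read-out, and no supporting measurement is available to explain why.

As far as these compounds go, whether a different group on this carbon, such as an amine, a carboxylic acid or a fluorine atom, would shift the number remains open. So does the question of whether the methoxy groups still present on compound 4 could also be replaced by hydrogen without a step beyond the scatter.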